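Thiazole-free notes: compound 1 to compound 3

The compounds below may be only part of what the source reports. "The series", "measured", "known", "first", "only" and "open" are said of these compounds alone.

That title is wrong: it names a ring and calls the compounds free of it, so please discard it. The corrected piece follows.

Working notes: from compound 1 to compound 3

Measured so far:
compound 1 `Fc1ccc(/C=N/Nc2nc(-c3ccc(C(F)(F)F)cc3)cs2)cc1F`: 14500 nM
compound 2 `COc1cc(/C=N/Nc2nc(-c3ccc(C(F)(F)F)cc3)cs2)c(Br)c(Br)c1OC`: > 100000 nM (a limit of the assay)

Going by the values given here, in a functional assay on HepG2 cells (Homo sapiens) for inhibition, read by MTT assay, with a stated time of 48 h (a lower number here means a stronger inhibitor, a higher number a weaker inhibitor), compound 1 gives 14500 nM, the only actual number so far. The one other result, for compound 2, is a limit and not a number.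

Compound 3 `Fc1ccc(/C=N/Nc2nc(-c3ccc(Br)cc3)cs2)cc1F` keeps the core of compound 1 and changes one substituent: bromo in place of trifluoromethyl on an aromatic carbon. This is bromo in place of trifluoromethyl on an aromatic carbon, para to a large group. Among the compounds with values here, no measured pair covers this change, so the expectation rests on compound 1 and the structural change alone. The expected result is a 1.0-fold lower number from compound 1 to compound 3 (0.02 log units; within the scatter), with no step beyond the scatter and no direction favoured in this assay. For compound 3 the estimated value is 14000 nM, with an expected range of 6000 nM to 35000 nM.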

Compound 3, half-maximal inhibitory concentration: > 100000 nM
Compound 3: only a limit was reported (the forecaster's own chance of this, stated with the estimate: 5%); at least 7.1-fold (0.85 log units) between middle value and limit.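

At this position, on an aromatic carbon para to a large group, the series now has its first readable step: in this assay, bromo in place of trifluoromethyl gives an at least 6.8-fold higher number from compound 1 to compound 3 (0.83 log units; beyond the scatter). Compound 3 gives > 100000 nM, which is a limit of the assay and not a number. The position is therefore not indifferent to this change, although the step is open-ended and its size is set by the limit: the limit of > 100000 nM in this assay, at which 2 of the 3 values shown sit.

On these data alone, the true size of the step remains open. Also open, as far as these compounds go, is whether a different group at this position, such as an amine, a nitrile or a carboxylic acid, would give a measurable number in this assay.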